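Trimming a Sulfonamide Tail Down to Methyl

The compounds below may be only part of what the source reports. "The series", "measured", "known", "first", "only" and "open" are said of these compounds alone.

Measured so far:
compound 1, `O=S(=O)(Nc1ccc(-c2nc3ccccc3o2)cc1)c1ccc(Cl)s1`: > 63000 nM
compound 2, `O=S(=O)(Nc1ccc(-c2nc3ccccc3o2)cc1)c1ccc(Cl)c(C(F)(F)F)c1`: > 63000 nM

In an assay on isolated protein for inhibition of malate dehydrogenase, mitochondrial (Sus scrofa), with stated times of 45 min and 30 min (on this read-out lower numbers stand for stronger inhibition and higher numbers for weaker inhibition), compound 1 gives > 63000 nM, which is a limit of the assay and not a number. Compound 2 likewise gives only a limit, > 63000 nM. (the limit of > 63000 nM in this assay, at which 2 of the 2 values shown sit). Compound 3, `CS(=O)(=O)Nc1ccc(-c2nc3ccccc3o2)cc1`, is not yet measured; it differs from compound 1 by methyl in place of 5-chlorothiophen-2-yl on a sulfonyl sulfur. With both shown values resting at the limit, no step between measured compounds can be drawn, and no change beyond the scatter is expected for a step that the limit leaves unreadable from compound 1 to compound 3. Compound 3 is therefore expected to give 100000 nM, between 40000 nM and 300000 nM, most likely reported again only as a limit.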

Compound 3, half-maximal inhibitory concentration: > 63000 nM
Compound 3 gave a limit, no number; the forecaster's own chance of this, stated with the estimate: 85%; the middle value lies beyond the limit too.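

Compound 1 and compound 3 each give a limit and not a number, so no step can be read between them: the limit of > 63000 nM in this assay, at which 3 of the 3 values shown sit.

The compounds shown leave open whether any group on the sulfonyl sulfur of the shared core can give a readable value.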